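Swapping iodo for methoxy on the shared core

The source may report more compounds than this note shows. Statements on the series, on what has been measured and on what is new or still open speak of the compounds shown alone.

Compound 1 (`NC(=O)c1cc(Cl)ccc1NC(=O)COc1ccccc1`) gives 3860 nM 
Compound 2 (`NC(=O)c1cc(I)ccc1NC(=O)COc1ccccc1`) gives 1680 nM 

In a functional assay on OVCAR-5 cells (Homo sapiens) for inhibition (on this read-out higher numbers stand for weaker inhibition of growth and lower numbers for stronger inhibition of growth), compound 2 holds the lower of the two numbers, at 1680 nM on this read-out, and its nearest neighbour is compound 1 at 3860 nM in the same test. Compound 3 (`COc1ccc(NC(=O)COc2ccccc2)c(C(N)=O)c1`) keeps the shared core and differs from compound 2 in one place: methoxy in place of iodo on an aromatic carbon. For the measured compounds named here, only one measured step touches that place. It is a 2.3-fold lower number from compound 1 to compound 2 (0.36 log units; beyond the scatter) (iodo in place of chloro on an aromatic carbon), which is modest but beyond the scatter. Going by the values given here, no methoxy compound has been measured, so the direction of the new step is uncertain. Iodo carries the lowest number so far, and the one other group tried at this place, in compound 1, stands higher. A modest step toward a higher number is therefore expected, of about the size of a 2.3-fold lower number from compound 1 to compound 2 (0.36 log units; beyond the scatter) but in reverse. The expected change is a 2.1-fold higher number from compound 2 to compound 3 (0.32 log units; beyond the scatter) in this assay on this estimate. Compound 3 is expected at 3500 nM within an estimated range of 1500 nM to 8000 nM in this assay as a measured value.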

Compound 3, concentration for 50% growth inhibition: 5400 nM
Compound 3: the middle estimate sits 1.5-fold (0.19 log units) below what was measured; measured number inside the range.
By their numbers in this assay, from the lowest: compound 2; then compounds 1 and 3 (each within the scatter of the next).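

In this assay, the change from iodo to methoxy gives a 3.2-fold higher number from compound 2 to compound 3 (0.51 log units; beyond the scatter) and so shows that the lower number at this place does not carry over to a second replacement of iodo. The change from chloro to methoxy gives a 1.4-fold higher number from compound 1 to compound 3 (0.15 log units; within the scatter) and leaves these two groups indistinguishable on this read-out, so that among the three groups only iodo stands apart, with its steps to both others beyond the scatter. Methoxy brings two heavy atoms and one hydrogen-bond acceptor where iodo has one heavy atom and none, but nothing available explains why iodo differs from the other two groups.

With only three groups at this place, the compounds shown cannot tell whether the lower number of compound 2 is particular to iodo or would also appear with bromo, the group closest to it among the halogens. They also leave open how an amine, a carboxylic acid or a longer alkoxy chain would behave on the same aromatic carbon, and whether any such group could go lower than iodo.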